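From methyl ester to dimethyl amide on a shared core

The source may report more compounds than this note shows. Statements on the series, on what has been measured and on what is new or still open speak of the compounds shown alone.

Compounds measured so far:
- compound 1 `COC(=O)Cn1c(=O)c(C)cn([C@@H]2O[C@H](CO[Si](C)(C)C(C)(C)C)[C@@]3(OS(=O)(=O)C=C3N)[C@H]2O[Si](C)(C)C(C)(C)C)c1=O` with > 152000 nM (a limit)
- compound 2 `Cc1cn([C@@H]2O[C@H](CO[Si](C)(C)C(C)(C)C)[C@@]3(OS(=O)(=O)C=C3N)[C@H]2O[Si](C)(C)C(C)(C)C)c(=O)n(CCO)c1=O` with 11300 nM
- compound 3 `CNC(=O)Cn1c(=O)c(C)cn([C@@H]2O[C@H](CO[Si](C)(C)C(C)(C)C)[C@@]3(OS(=O)(=O)C=C3N)[C@H]2O[Si](C)(C)C(C)(C)C)c1=O` with >= 250000 nM (a limit)

In a functional assay on CCRF-CEM cells (Homo sapiens) (on this read-out lower numbers stand for higher toxicity in this test and higher numbers for lower toxicity in this test), compound 1 reads > 152000 nM as a limit and not a number. It therefore offers no exact starting point. Compound 4 `Cc1cn([C@@H]2O[C@H](CO[Si](C)(C)C(C)(C)C)[C@@]3(OS(=O)(=O)C=C3N)[C@H]2O[Si](C)(C)C(C)(C)C)c(=O)n(CC(=O)N(C)C)c1=O` differs from it by one change dimethylamino in place of methoxy on a carbonyl carbon that puts dimethylamino in place of methoxy on a carbonyl carbon.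

The closest measured change, methylamino in place of methoxy on a carbonyl carbon, is a step that the two limits leave unreadable from compound 1 to compound 3 and so gives no size. Compound 3 also reads >= 250000 nM as a limit in this assay and not as a number. Only the change to hydroxymethyl moves the read-out, as an at least 13-fold lower number from compound 1 to compound 2 (1.12 log units; beyond the scatter) shows, and an at least 22-fold higher number from compound 2 to compound 3 (1.34 log units; beyond the scatter) is just as large on the way back. Compound 4 keeps the carbonyl, as compound 3 does, so no large step is expected, and a reading at a limit is quite likely. The estimated change is a step that the limit leaves unreadable from compound 1 to compound 4 in this expectation. For compound 4 the estimate is 200000 nM, with an expected range from 80000 nM to 400000 nM in this test.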

Compound 4, half-maximal cytotoxic concentration: 245000 nM
Estimate against measurement, compound 4: 1.2-fold (0.09 log units) below; the measured number falls inside the stated range.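

In this assay, among the compounds shown here, compound 4 gives the first exact number for a compound that keeps the carbonyl on this chain, where compound 1 and compound 3 offer only limits. Dimethylcarbamoyl in place of hydroxymethyl therefore has a measured size: a 22-fold higher number from compound 2 to compound 4 (1.34 log units; beyond the scatter). Methyl in place of hydrogen on the amide-type nitrogen gives an at least 1.0-fold lower number from compound 3 to compound 4 (0.00 log units; that floor lies within the scatter), so this step shows no change beyond the usual scatter, though compound 3 is only a limit and the true gap could be larger.

From the compounds shown here alone, the step from compound 1 to compound 4 cannot be read, so how the methyl ester compares with the dimethyl amide stays open. Also open, going by these compounds, is how a carboxylic acid, or a longer chain ending in an amine, would read on this saturated chain carbon.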